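Chain-shortened benzylamine sulfonamides: bromo, chloro, methoxy variants

This account rests on a few compounds, and the source may have more. Where it says the series, first, only, none or still open, it means among the compounds named here.

Compound 1 `O=S(=O)(NCCCCNCc1ccc(Br)cc1)c1cc(C(F)(F)F)cc(C(F)(F)F)c1` gives 1700 nM in a functional assay on BXPC-3 cells (Homo sapiens) for inhibition, read by MTT assay, with a stated time of 72 h (a lower number here means a stronger inhibitor of growth, a higher number a weaker inhibitor of growth), the lowest of the three numbers measured. Compound 2 `O=S(=O)(NCCCNCc1ccccc1)c1cc(C(F)(F)F)cc(C(F)(F)F)c1` gives 13000 nM and compound 3 `O=S(=O)(NCCCNCc1cccc(Cl)c1)c1cc(C(F)(F)F)cc(C(F)(F)F)c1` gives 3800 nM. The step of a 7.6-fold higher number from compound 1 to compound 2 (0.88 log units; beyond the scatter) and the step of a 2.2-fold higher number from compound 1 to compound 3 (0.35 log units; beyond the scatter) both show a modest rise; between them, a 3.4-fold lower number from compound 2 to compound 3 (0.53 log units; beyond the scatter) shows chloro in place of hydrogen on an aromatic carbon pulling the number back down. Compound 4 `COc1cccc(CNCCCNS(=O)(=O)c2cc(C(F)(F)F)cc(C(F)(F)F)c2)c1` differs from compound 1 by (3-methoxybenzyl)amino in place of ((4-bromobenzyl)amino)methyl on a saturated chain carbon, three bonds along the chain from a sulfonamide nitrogen. The two steps from compound 1 bear on it directly; both go upward, so a modest rise is expected here too, likely between the two. For compound 4 the estimate is 6000 nM (range 2500 nM to 15000 nM), meaning an expected step of a 3.5-fold higher number from compound 1 to compound 4 (0.55 log units; beyond the scatter).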

Compound 4, concentration for 50% growth inhibition: 1700 nM
Compound 4: the middle estimate sits 3.5-fold (0.55 log units) above what was measured; measured number below the stated range.
By their numbers in this assay, from the lowest: compounds 1 and 4 (each within the scatter of the next); then compound 3; then compound 2.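

Methoxy on the aromatic carbon gives a 2.2-fold lower number from compound 3 to compound 4 (0.35 log units; beyond the scatter) and a 7.6-fold lower number from compound 2 to compound 4 (0.88 log units; beyond the scatter) so this group recovers more of the number than chloro did. With (3-methoxybenzyl)amino, the replacement of ((4-bromobenzyl)amino)methyl shows no change at the digits printed from compound 1 to compound 4 (within the scatter) whereas the same kind of replacement raised the number with the chloro and unsubstituted benzyl groups.

Still open, on these data alone, is how much of that replacement belongs to the chain and how much to the aromatic substituent, and whether a nitrile or a hydroxyl on the aromatic carbon would match methoxy. No measurement at hand explains any of these steps.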